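Swapping the Aryl on the Ring Nitrogen for tert-Butyl

The source may hold more compounds than are shown below. What is called first, only, known or untested is meant among the compounds shown, and "the series" means these compounds.

Compound 1 `CC(C)(C)c1cc(NC(=O)Nc2cc(C(F)(F)F)cc(C(F)(F)F)c2)n(-c2ccccc2)n1`: -0.5 degrees C
Compound 2 `Cc1ccc(-n2nc(C(C)(C)C)cc2NC(=O)Nc2cc(C(F)(F)F)cc(C(F)(F)F)c2)cc1`: -0.5 degrees C
Compound 3 `CC(C)(C)c1cc(NC(=O)Nc2cc(C(F)(F)F)cc(C(F)(F)F)c2)n(-c2ccc(F)cc2)n1`: -0.6 degrees C

In an assay on isolated protein for inhibition of serine/threonine-protein kinase 10 (Homo sapiens), read by thermal shift assay, tested at 10 uM (a higher number here means that the compound stabilises the target more against heat, a lower number that the compound stabilises the target less), compound 3 sits within the scatter of both compound 1 and compound 2, so the three cannot be ordered. The measured steps, no change at the digits printed from compound 1 to compound 2 (within the scatter), a number 0.10 degrees C lower from compound 1 to compound 3 (within the scatter) and a number 0.10 degrees C lower from compound 2 to compound 3 (within the scatter), all alter the ring attached to the ring nitrogen and none moves beyond the scatter. Compound 4 `CC(C)(C)c1cc(NC(=O)Nc2cc(C(F)(F)F)cc(C(F)(F)F)c2)n(C(C)(C)C)n1` takes this further: tert-butyl in place of 4-fluorophenyl on an aromatic nitrogen. This exchange is larger than any measured step, so the range is set wider, but no direction is indicated. Compound 4 is expected to give -0.5 degrees C in this assay, with a likely range from -1.5 degrees C to 0.6 degrees C. For compound 4 this amounts to an expected step of a number 0.10 degrees C higher from compound 3 to compound 4 (within the scatter).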

Compound 4, shift of the target's melting temperature: -0.7 degrees C
Compound 4: the middle estimate sits 0.20 degrees C above what was measured; the range from low to high includes it.
By their numbers in this assay, from the lowest: compounds 4, 3, 1 and 2 (each within the scatter of the next).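

At the ring nitrogen, the steps in this assay are a number 0.10 degrees C lower from compound 3 to compound 4 (within the scatter) and a number 0.20 degrees C lower from compound 2 to compound 4 (within the scatter) and a number 0.20 degrees C lower from compound 1 to compound 4 (within the scatter) on exchanging each aryl group for tert-butyl. The absence of any step beyond the scatter therefore now extends from changes on the aromatic ring to a group with no ring at all. Nothing available explains this result.

On these data alone, whether an amine, a carboxylic acid or a longer chain on this nitrogen would move the reading remains open. So does the effect of any change elsewhere on the shared core.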